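The source may report more compounds than this note shows. Statements on the series, on what has been measured and on what is new or still open speak of the compounds shown alone.

Among the compounds with values here, in an assay on HL-60 cells for inhibition of P-selectin (Homo sapiens) (on this read-out lower numbers stand for stronger inhibition and higher numbers for weaker inhibition), compound 2 `O=C(O)CCCNC(=O)[C@]1(O)C[C@@H](O)[C@@H](O)[C@H](O)C1` gives 40000000 nM, the only number reported among the measured compounds. Compound 1 `O=C(O)CNC(=O)[C@]1(O)C[C@@H](O)[C@@H](O)[C@H](O)C1` reaches only a limit of this assay, > 50000000 nM. Within the data shown here, the one measured step, an at least 1.2-fold lower number from compound 1 to compound 2 (0.09 log units; that floor lies within the scatter), is thus a floor rather than a settled size. Compound 3 `O=C(O)CCCCCNC(=O)[C@]1(O)C[C@@H](O)[C@@H](O)[C@H](O)C1` carries the same change one stage further: 2-carboxyethyl in place of carboxy on a saturated chain carbon, three bonds along the chain from an amide-type nitrogen. Among the measured compounds shown here, the sole precedent for lengthening this chain, from compound 1 to compound 2, gave a step whose measured floor lies within the scatter of this assay, with compound 1 at the limit of > 50000000 nM in this assay, at which 1 of the 2 values shown sits, so no movement beyond the scatter is expected here either; if anything, a small drift toward a lower number would match that precedent. Compound 3 is therefore expected to give about 25000000 nM in this assay, within 5000000 nM to 100000000 nM, an expected step of a 1.6-fold lower number from compound 2 to compound 3 (0.20 log units; within the scatter) that stays inside the scatter.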

Compound 3, half-maximal inhibitory concentration: > 50000000 nM
Compound 3 ended at the assay's limit; the forecaster's own chance of this, stated with the estimate: 40%; at least 2.0-fold (0.30 log units) between middle value and limit.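

Taking the chain one stage further, with 2-carboxyethyl in place of carboxy three bonds along the chain from the amide-type nitrogen, gives in this assay an at least 1.2-fold higher number from compound 2 to compound 3 (0.09 log units; that floor lies within the scatter), so this change shows no move toward a lower number. The step between compound 1 and compound 3 cannot be read, since both of its values are limits. Compound 3 thus joins compound 1 at the assay's ceiling, which leaves compound 2 as the only compound with a number and the chain lengths shown without a readable order: the limit of > 50000000 nM in this assay, at which 2 of the 3 values shown sit.

On these data alone, how far compound 1 and compound 3 lie beyond that limit remains open, and with it whether compound 2 truly differs from either. Also open, as far as these compounds go, is whether an amine or a phenyl ring in place of the carboxy group would bring the number down on the shared core.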